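Compound 1 to compound 3: 3-nitrophenyl for 4-fluorophenyl

The compounds below may be only part of what the source reports. "The series", "measured", "known", "first", "only" and "open" are said of these compounds alone.

Measured in a functional assay on HT-29 cells (Homo sapiens) for antiproliferative activity, read by MTT assay, with a stated time of 24 h; a lower number here means a stronger inhibitor, a higher number a weaker inhibitor:
Compound 1 `COc1ccc(C(=O)/C=C/c2ccc(F)cc2)c2c1C=CC(C)(C)O2` (> 10000 nM)
Compound 2 `COc1ccc(C(=O)/C=C/c2ccc(-c3ccccc3)cc2)c2c1C=CC(C)(C)O2` (> 10000 nM)

Compound 1 stands on a limit (> 10000 nM) and not on a number. Compound 2 also stands on a limit (> 10000 nM) and not on a number. Both values sit at the limit of > 10000 nM in this assay, at which 2 of the 2 values shown sit, and give no position beyond it. Among the compounds with values here, the one measured step is a step that the two limits leave unreadable from compound 1 to compound 2 and it offers neither a size nor a direction. Compound 3 `COc1ccc(C(=O)/C=C/c2cccc([N+](=O)[O-])c2)c2c1C=CC(C)(C)O2` differs from compound 1 by 3-nitrophenyl in place of 4-fluorophenyl on a double-bonded chain carbon bound to a double-bonded chain carbon with 3-nitrophenyl in place of 4-fluorophenyl on a double-bonded chain carbon bound to a double-bonded chain carbon. With only a step that the two limits leave unreadable from compound 1 to compound 2 to go on, no step beyond the scatter is expected in this assay and another limit is likely. The expected step is a step that the limit leaves unreadable from compound 1 to compound 3 and it is only an estimate. For compound 3 the estimated value is 15000 nM (expected range 5000 nM to 40000 nM).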

Compound 3, half-maximal inhibitory concentration: 4260 nM
Compound 3: the middle estimate sits 3.5-fold (0.55 log units) above what was measured, outside the stated range (below it).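

In this assay, within the data shown here, replacing 4-fluorophenyl with 3-nitrophenyl gives the first readable step here: an at least 2.3-fold lower number from compound 1 to compound 3 (0.37 log units; beyond the scatter). Compound 3 therefore shows that a change at this place, on a double-bonded chain carbon bound to a double-bonded chain carbon, can bring a value that is a number and not a limit. The true size of the step stays unknown, because the value of compound 1 is a limit: the limit of > 10000 nM in this assay, at which 2 of the 3 values shown sit.

The compounds shown leave open whether the step belongs to the nitro group itself or to where it sits on the ring. Going by these compounds, whether 4-nitrophenyl, or an amine in place of the nitro group, would give a similar value also remains open.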